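Swapping cyano for nitro on compound 3

This account rests on a few compounds, and the source may have more. Where it says the series, first, only, none or still open, it means among the compounds named here.

Compound 1 `Cn1cncc1[C@@](N)(c1ccc(C#N)cc1)c1cc2cc(C#N)cc(-c3cccc(C#N)c3)c2o1`: 2 nM
Compound 2 `Cn1cncc1[C@@](N)(c1ccc(C#N)cc1)c1cc2cc([N+](=O)[O-])cc(-c3ccccc3)c2o1`: 5.9 nM
Compound 3 `COc1cccc(-c2cc(C#N)cc3cc([C@](N)(c4ccc(C#N)cc4)c4cncn4C)oc23)c1`: 1.5 nM

These numbers all come from a functional assay on QG-56 cells (Homo sapiens) for antiproliferative activity; on this read-out higher numbers stand for weaker inhibition and lower numbers for stronger inhibition. Compound 3 (1.5 nM) sits at the low end of the three, level within the scatter with compound 1 (2 nM), while compound 2 (5.9 nM) stands higher, beyond the scatter.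

The next compound is compound 4 `COc1cccc(-c2cc([N+](=O)[O-])cc3cc([C@](N)(c4ccc(C#N)cc4)c4cncn4C)oc23)c1`, which changes one group of compound 3: nitro in place of cyano on an aromatic carbon. In words, nitro replaces cyano on an aromatic carbon, meta to a 3-methoxyphenyl group.

Among the compounds with values here, only one measured step connects these compounds (a 1.3-fold lower number from compound 1 to compound 3 (0.12 log units; within the scatter)). It swaps methoxy for cyano at a different place and stays within the scatter, so it says little about the new change. Within the data shown here, no measured step swaps cyano for nitro directly.

The nearest hint is compound 2 (5.9 nM), which carries nitro on the core but also lacks the methoxy group, so it differs from compound 3 in more than one place. A small move toward a higher number in this assay, near the edge of the scatter, is therefore expected (a 2.0-fold higher number from compound 3 to compound 4 (0.30 log units; within the scatter)). The estimated value for compound 4 is 3 nM, with an expected range of 1.2 nM to 8 nM.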

Compound 4, half-maximal inhibitory concentration: 1.1 nM
Compound 4: middle estimate off by 2.7-fold (0.44 log units), on the high side; the whole stated range lies above it.
By their numbers in this assay, from the lowest: compounds 4, 3 and 1 (each within the scatter of the next); then compound 2.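

In this assay, the direct swap at this position, an aromatic carbon of the shared core meta to a 3-methoxyphenyl group, gives a 1.4-fold lower number from compound 3 to compound 4 (0.13 log units; within the scatter) and so leaves nitro and cyano level within the scatter. Within the data shown here, with nitro held in place, the one change that separates compound 2 from compound 4 lies elsewhere: methoxy in place of hydrogen gives a 5.4-fold lower number from compound 2 to compound 4 (0.73 log units; beyond the scatter), which shows that nitro on the core does not by itself bring a high number in this cell assay. No measurement shown here gives a reason for either result.

On these data alone, only nitro and cyano can be compared at this position, so it remains open whether an amine or a carboxylic acid there would keep the number as low. Among these compounds, the step from hydrogen to methoxy is seen only with nitro on the core, so its size with cyano at that position also remains unknown.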